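Removing the Methoxy Group from a Benzyl Substituent

A few compounds are considered here, and "the series" means these few. Any claim that something is new, unique, unknown or untested is made for them only; others in the source may bear on it.

Of the compounds shown here, three built on one shared core have been measured in a functional assay on FM3A cells (Mus musculus) for inhibition, read by cell counting, with a stated time of 2 days; on this read-out higher numbers stand for weaker inhibition and lower numbers for stronger inhibition. Compound 1 `C=C(Br)C(=O)Nc1cccc(-c2cn3nc(-c4ccc(CC)cc4)sc3n2)c1` gives 3300 nM. Compound 2 `C=C(Br)C(=O)Nc1cccc(-c2cn3nc(-c4ccc(F)cc4)sc3n2)c1` gives 610 nM, and compound 3 `C=C(Br)C(=O)Nc1cccc(-c2cn3nc(Cc4cccc(OC)c4)sc3n2)c1` gives 1100 nM. Among these three numbers compound 3 holds the second highest place. Its nearest neighbour is compound 2, separated by a 1.8-fold higher number from compound 2 to compound 3 (0.26 log units; within the scatter), a gap within the scatter; its furthest is compound 1, separated by a 3.0-fold lower number from compound 1 to compound 3 (0.48 log units; beyond the scatter). The largest step seen is a 5.4-fold lower number from compound 1 to compound 2 (0.73 log units; beyond the scatter).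

Compound 4 `C=C(Br)C(=O)Nc1cccc(-c2cn3nc(Cc4ccccc4)sc3n2)c1` differs from compound 3 in one place: hydrogen in place of methoxy on an aromatic carbon. Going by the values given here, no measured step removes a methoxy group, so none bears on this change directly. All three steps exchange the group on the same aromatic carbon of the core, and they run from a gap within the scatter up to a modest one. Since compound 2 and compound 3 carry different pendant rings yet sit within the scatter of each other, the smaller change to compound 4 is expected to move the number little, a 1.3-fold higher number from compound 3 to compound 4 (0.10 log units; within the scatter), in no certain direction. Compound 4 is therefore estimated at 1400 nM in this assay, within a range from 550 nM to 3800 nM.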

Compound 4, half-maximal inhibitory concentration: 3000 nM
The estimate for compound 4 lay 2.1-fold (0.33 log units) below the measured number, and the stated range covers the measured number.
By their numbers in this assay, from the lowest: compounds 2 and 3 (each within the scatter of the next); then compounds 4 and 1 (each within the scatter of the next).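

In this assay the methoxy group proves to count at this position: taking it away alone gives a 2.7-fold higher number from compound 3 to compound 4 (0.44 log units; beyond the scatter) and this step lies beyond the scatter, although the pendant rings of compound 2 and compound 3 had stood within the scatter of each other. The benzyl group of compound 4 also stands apart from the 4-fluorophenyl group, with a 4.9-fold higher number from compound 2 to compound 4 (0.69 log units; beyond the scatter) beyond the scatter, whereas a 1.1-fold lower number from compound 1 to compound 4 (0.04 log units; within the scatter) lies within the scatter and so does not separate the benzyl group from the 4-ethylphenyl group. Nothing available explains the effect of the methoxy group.

The compounds shown leave open whether a hydroxy, amino or ethoxy group on the same aromatic carbon would give a number nearer that of compound 3 or that of compound 4. They also leave open whether a methoxy group on another carbon of this ring would have the same effect.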